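The source may report more compounds than this note shows. Statements on the series, on what has been measured and on what is new or still open speak of the compounds shown alone.

Measured compounds:
compound 1, `CC(=O)Nc1c(C)nc2c(CCc3ccccc3)cccn12` — 12 mg/kg
compound 2, `CNC(=O)Nc1c(C)nc2c(OCc3ccccc3)cccn12` — 3.5 mg/kg

Both compounds were tested in a functional assay on the whole organism with Rattus norvegicus as the target; on this read-out higher numbers stand for an effect only at larger amounts of compound and lower numbers for an effect already at smaller amounts. Compound 2 stands at the lower of the two numbers, and compound 1 at the higher one, a gap that lies beyond the usual scatter of repeated measurements.

Compound 3, `Cc1nc2c(OCc3ccccc3)cccn2c1NCc1ccccc1`, has not yet been measured. It differs from compound 2 in a single place: benzyl in place of methylcarbamoyl on a nitrogen on an aromatic ring. For the measured compounds named here, no measured pair shows what this kind of exchange does, so nothing in the data gives a direct precedent. A moderate step toward a higher number, beyond the scatter, is what we expect, a 2.3-fold higher number from compound 2 to compound 3 (0.36 log units; beyond the scatter). Compound 3 is estimated at 8 mg/kg in this assay, with a plausible range from 3 mg/kg to 25 mg/kg.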

Compound 3, dose for half-maximal effect: 2.5 mg/kg
Compound 3: middle estimate off by 3.2-fold (0.51 log units), on the high side, and the stated range ends above it.
By their numbers in this assay, from the lowest: compounds 3 and 2 (each within the scatter of the next); then compound 1.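

In this assay, putting benzyl in place of methylcarbamoyl on this nitrogen gives a 1.4-fold lower number from compound 2 to compound 3 (0.15 log units; within the scatter), so the two compounds cannot be told apart on this read-out. In this pair, then, the nitrogen on the aromatic ring carries a group with no ring, a carbonyl, a hydrogen-bond donor and a hydrogen-bond acceptor, or one with a six-membered aromatic ring and neither donor nor acceptor, and the dose stays level. No measurement at hand explains why these two different groups end up level. From the compounds shown here alone, whether a free amine or a longer chain ending in the aromatic ring would keep this level on the same nitrogen remains open. Compound 1 differs from compound 2 in more than one place, so it does not settle this question.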